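From Chlorophenyl to Dimethylphenyl in a Carbamate Series

This account rests on a few compounds, and the source may have more. Where it says the series, first, only, none or still open, it means among the compounds named here.

Measured compounds:
compound 1 `COc1ccc(N2CCN(CCC(OC(N)=O)c3ccc(Cl)cc3)CC2)cc1`: 51%
compound 2 `COc1ccc(N2CCN(CCC(OC(N)=O)c3ccccc3)CC2)c(OC)c1`: 19%
compound 3 `NC(=O)OC(CCN1CCN(c2ccc(OC(F)(F)F)cc2)CC1)c1ccccc1`: 18%

In a functional assay on the whole organism for inhibition, with Mus musculus as the target, in the writhing test, with a stated time of 1 h, at a dose of 10 mg/kg by the oral route (on this read-out lower numbers stand for less inhibition and higher numbers for more inhibition at the one dose given (going by the name of the read-out)), compound 1 gives 51%, the highest of the three numbers. Compound 2 gives 19% in this assay, and compound 3 gives 18%, both lying beyond the scatter below compound 1. Compound 4 `COc1ccc(N2CCN(CCC(OC(N)=O)c3ccc(C)cc3C)CC2)cc1` has not yet been measured. It differs from compound 1 by 2,4-dimethylphenyl in place of 4-chlorophenyl on a saturated chain carbon bound to an oxygen next to a carbonyl group and a saturated chain carbon. Within the data shown here, no pair of measured compounds shows a change of this kind, so its effect cannot be read from the numbers given. The step of a number 16 percentage points lower from compound 1 to compound 4 (beyond the scatter) is therefore estimated as a modest loss, with a step no larger than the scatter also possible. Compound 4 is expected to give 35%, within a range from 10% to 60%.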

Compound 4, a percentage reported as inhibition, in the whole organism at one dose (the size of the read-out at that dose, not a potency): 62%
Estimate against measurement, compound 4: 27 percentage points below, outside the stated range (above it).
By their numbers in this assay, from the lowest: compounds 3 and 2 (each within the scatter of the next); then compound 1; then compound 4.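

In this assay, putting 2,4-dimethylphenyl in place of 4-chlorophenyl on this saturated chain carbon gives a number 11 percentage points higher from compound 1 to compound 4 (beyond the scatter). Among these compounds, this is the first single change read at this place, and it shows that, for this pair at this one dose, the chlorine is not needed to keep the inhibition and that a larger carbon-only aryl group is accepted here. Nothing available explains the rise.

From the compounds shown here alone, it remains open whether a single methyl group on the phenyl ring would give the same step, and how a pyridine ring would fare at this place. Going by these compounds, whether the step holds at other doses also remains open.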